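A few compounds are considered here, and "the series" means these few. Any claim that something is new, unique, unknown or untested is made for them only; others in the source may bear on it.

Measured so far:
Compound 1, `CC(C)COC(=O)N1CCN(C(=O)c2nc(Nc3cc(C4CC4)[nH]n3)c3cc(Cl)ccc3n2)C[C@H]1C`, in an assay for inhibition of serine/threonine-protein kinase PAK 4 (Homo sapiens), read by FRET and Z'-LYTE, with a stated time of 60 min, tested at 5 uM, in the presence of a further agent that is not named here (on this read-out higher numbers stand for a stronger effect at the one concentration tested and lower numbers for a weaker effect), gives 30.7%.
Compound 2, `C[C@@H]1CN(C(=O)c2nc(Nc3cc(C4CC4)[nH]n3)c3cc(Cl)ccc3n2)CCN1C(=O)OC(C)(C)C`, in this assay gives 22.7%.

Compound 2 stands beside compound 1 on these two numbers: the step of a number 8 percentage points lower from compound 1 to compound 2 (within the scatter) lies within the scatter, so the two cannot be told apart with confidence. Both share one core and differ only in the group that sits on an oxygen next to a carbonyl group.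

Compound 3, `CC(OC(=O)C(C)C)OC(=O)N1CCN(C(=O)c2nc(Nc3cc(C4CC4)[nH]n3)c3cc(Cl)ccc3n2)C[C@H]1C`, is the next compound in this series and has not yet been measured. It differs from compound 2 by 1-((isopropylcarbonyl)oxy)ethyl in place of tert-butyl on an oxygen next to a carbonyl group.

Among the measured compounds shown here, the only measured step that bears on this change is the one from compound 1 to compound 2, which exchanged one alkyl group for another at the same place and gave a number 8 percentage points lower from compound 1 to compound 2 (within the scatter). That step changed nothing beyond the scatter. On that single piece of evidence, the step in this assay is expected to be small in either direction, estimated as a number 2.3 percentage points higher from compound 2 to compound 3 (within the scatter). Compound 3 is therefore expected to give about 25%, with a likely range from 8% to 42%.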

Compound 3, a percentage reported as inhibition, at one concentration (the size of the read-out at that concentration, not a potency): 25.8%
Estimate against measurement, compound 3: 0.8 percentage points below, within the range that was stated.
By their numbers in this assay, from the lowest: compounds 2, 3 and 1 (each within the scatter of the next).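

In this assay the step from tert-butyl to 1-((isopropylcarbonyl)oxy)ethyl on an oxygen next to a carbonyl group is a number 3.1 percentage points higher from compound 2 to compound 3 (within the scatter) and the step from isobutyl to the same group is a number 4.9 percentage points lower from compound 1 to compound 3 (within the scatter) so neither separates the new compound from the earlier two. Among the compounds shown here, the earlier pair compared only two groups made of carbon, whereas this group brings 8 heavy atoms in place of 4, with 2 oxygen atoms and 2 hydrogen-bond acceptors, and this larger change at the same place still leaves the three numbers within the usual scatter of one another. Nothing measured alongside these compounds gives a reason for this result.

From the compounds shown here alone, it remains open whether a quite different group at this place, such as an amine, a carboxylic acid or a longer chain, would give a step beyond the scatter in this assay and so show that the position can influence the read-out at all. Each compound was read at one concentration only, so these numbers leave any difference in potency among the three unresolved.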